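The source may hold more compounds than are shown below. What is called first, only, known or untested is meant among the compounds shown, and "the series" means these compounds.

Measured compounds:
Compound 1, `Cc1ncc(-c2ccccc2NCC2=NCCN2)o1`: in a functional assay for activation of Alpha-1B adrenergic receptor (Homo sapiens), read by calcium flux (a higher number here means that more compound is needed for the effect, a lower number that less compound is needed), compound 1 gives only a limit, < 5020 nM.
Compound 2, `Cc1nc(-c2ccccc2NCC2=NCCN2)cs1`: in this assay compound 2 gives 69.2 nM.
Compound 3, `c1csc(-c2ccccc2NCC2=NCCN2)c1`: in this assay compound 3 gives 5.75 nM.

Compound 1 stands at a limit of this assay (the limit of < 5020 nM in this assay, at which 1 of the 3 values shown sits), so where it lies relative to compound 2 and compound 3 cannot be read; the steps a step that the limit leaves unreadable from compound 1 to compound 2 and a step that the limit leaves unreadable from compound 1 to compound 3 stay unreadable. Among the compounds with values here, the only readable step, a 12-fold lower number from compound 2 to compound 3 (1.08 log units; beyond the scatter), shows that swapping one five-membered aromatic ring for another on the shared core can shift the number by a large amount.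

Compound 4, `c1ccc(-c2cnoc2)c(NCC2=NCCN2)c1`, differs from compound 1 by 1,2-oxazol-4-yl in place of 2-methyl-1,3-oxazol-5-yl on an aromatic carbon. Within the data shown here, no measured step covers this change directly, and the starting point is itself only a limit, so the expectation rests on the observation that such ring swaps move the number strongly in this assay, as compound 2 to compound 3 shows in a 12-fold lower number from compound 2 to compound 3 (1.08 log units; beyond the scatter). For compound 4 a value of 300 nM is estimated, within 40 nM to 3000 nM. The expected step that the limit leaves unreadable from compound 1 to compound 4 is therefore uncertain in size and direction.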

Compound 4, half-maximal effective concentration: < 100000 nM
Compound 4 ended at the assay's limit (the forecaster's own chance of this, stated with the estimate: 20%); the middle value does not contradict the limit.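

Within the data shown here, compound 4 gives < 100000 nM as a limit, and no step from it to compound 1, compound 2 or compound 3 can be read. Where compound 1 and compound 4 lie relative to each other, and to compound 2 and compound 3, stays open.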